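The compounds below may be only part of what the source reports. "The series", "measured", "known", "first", "only" and "open" are said of these compounds alone.

In a toxicity assay on HEK-293T cells (Homo sapiens) for cytotoxicity, read by MTT assay, with a stated time of 48 h (on this read-out higher numbers stand for weaker inhibition and lower numbers for stronger inhibition), compound 1 `C=C1[C@H](OCC(C)C)[C@@H](OC(C)=O)[C@@H](OC(C)=O)C(C)(C)/C=C/[C@H](C)[C@H](OC(=O)c2ccccc2)[C@@]2(O)C[C@@](C)(OC(C)=O)[C@H](OC(C)=O)[C@@H]2[C@H]1OCC(C)C` reads > 100000 nM and this is a limit of the assay, not a number. Compound 2 `C=C1[C@H](OC(C)=O)[C@@H](OC(C)=O)[C@@H](O)C(C)(C)/C=C/[C@H](C)[C@H](OC(=O)c2ccccc2)[C@@]2(O)C[C@@](C)(O)[C@H](OC(C)=O)[C@@H]2[C@H]1OCC(C)C` reads > 100000 nM and this too is a limit. Compound 3 `C=C1[C@H](O)[C@@H](OC(=O)c2cccc(C)c2)[C@@H](O)C(C)(C)/C=C/[C@H](C)[C@H](OC(=O)c2ccccc2)[C@@]2(O)C[C@@](C)(O)[C@H](OC(C)=O)[C@@H]2[C@H]1OCC(C)C` reads 31300 nM as a true number. The picture so far is thus the limit of > 100000 nM in this assay, at which 2 of the 3 values shown sit, and little else. Compound 4 `C=C1[C@H](OC(C)=O)[C@@H](OC(C)=O)[C@@H](OC(C)=O)C(C)(C)/C=C/[C@H](C)[C@H](OC(=O)c2ccccc2)[C@@]2(O)C[C@@](C)(OC(C)=O)[C@H](OC(C)=O)[C@@H]2[C@H]1OCC(C)C` keeps the core of compound 1 but has acetyl in place of isobutyl on an oxygen on a saturated carbon, with acetyl in place of isobutyl on an oxygen on a saturated carbon as the count of that change. Within the data shown here, no measured pair shows this change, so in this assay no shift beyond the scatter is expected. The estimated step of a number no higher from compound 1 to compound 4 (the limit leaves the size open) is expected to be small. For compound 4 the expected value is 100000 nM with an estimated range from 40000 nM to 250000 nM and a fair chance of another limit.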

Compound 4, half-maximal inhibitory concentration: 26100 nM
The estimate for compound 4 lay 3.8-fold (0.58 log units) above the measured number; the measured number lies below the stated range.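

In this assay, acetyl in place of isobutyl on an oxygen on a saturated carbon gives an at least 3.8-fold lower number from compound 1 to compound 4 (0.58 log units; beyond the scatter), so the group at this place does affect the read-out and stronger inhibition comes with acetyl. The value of compound 1 is a limit, so the full size of this step stays open, and such limits are common in this small set: the limit of > 100000 nM in this assay, at which 2 of the 4 values shown sit.

The compounds shown leave open whether a longer chain, such as butanoyl, or a chain carrying an amine would move the number further at this place.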